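The source may hold more compounds than are shown below. What is called first, only, known or untested is meant among the compounds shown, and "the series" means these compounds.

Measured so far:

compound 1, `COc1ccc(OCC(=O)Nc2cccc(NC(=O)c3ccc(N(C)C)cc3)c2)cc1F` — 1820 nM
compound 2, `O=C(COc1ccc2c(=O)ccoc2c1)Nc1cccc(NC(=O)c2ccc(F)cc2)c1` — 129 nM

Both numbers come from an assay on isolated protein for inhibition of Rho-associated protein kinase 1 (Homo sapiens), read by scintillation counting, radiometric assay and 33P incorporation, with a stated time of 40 min, in the presence of a further agent that is not named here; a lower number here means a stronger inhibitor, a higher number a weaker inhibitor. Compound 2 has the lower of the two numbers; compound 1 sits at a higher number, and the gap between them lies beyond the usual scatter. The two compounds differ in more than one place, so nothing is read from that gap about any single change.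

Compound 3, `Cc1cc(C(=O)Nc2cccc(NC(=O)COc3ccc4c(=O)ccoc4c3)c2)ccc1C(F)(F)F`, is not yet measured in this assay. Against compound 2 the change is a group of 11 heavy atoms (8 carbon, 3 fluorine; one six-membered aromatic ring of carbon only) in place of a group of 7 heavy atoms (6 carbon, 1 fluorine; one six-membered aromatic ring of carbon only), on a carbonyl carbon. The shared core and the rest of the molecule are kept.

Going by the values given here, no measured pair shows this kind of exchange on the carbonyl carbon, so there is no step to lean on. The expected step from compound 2 to compound 3 in this assay, a 1.2-fold higher number from compound 2 to compound 3 (0.07 log units; within the scatter), is small, within or close to the scatter, and its direction is uncertain. Compound 3 is therefore expected to give about 150 nM in this assay, with a range from 40 nM to 550 nM.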

Compound 3, half-maximal inhibitory concentration: 460 nM
For compound 3 the middle estimate is 3.1-fold (0.49 log units) below the measured one, within the range that was stated.
By their numbers in this assay, from the lowest: compound 2; then compound 3; then compound 1.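

On the carbonyl carbon whose other neighbour is the amide-type nitrogen, the series does respond to exchange: in this assay, the group of 11 heavy atoms in place of 4-fluorophenyl gives a 3.6-fold higher number from compound 2 to compound 3 (0.55 log units; beyond the scatter), a modest step beyond the scatter. Going by these compounds alone, this is the first reading of a single place; the earlier pair differs in more than one place and gave no such reading. Both groups have one six-membered aromatic ring of carbon only, no hydrogen-bond donors or acceptors and no net charge, so the step appears without a change in any of these counted features, and nothing measured here accounts for it.

Within the data shown here, the entering group brings a methyl and a trifluoromethyl in place of the single fluorine in one exchange, so the share of each in the step remains unresolved. Also open, from the compounds shown here alone, is whether any group at this carbonyl carbon gives a lower number than compound 2 does, for example a phenyl ring carrying a nitrile or a carboxylic acid, and whether the step holds on another core.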